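Swapping a proline amide for a dimethylamide on a shared core

This account rests on a few compounds, and the source may have more. Where it says the series, first, only, none or still open, it means among the compounds named here.

Compound 1 has the structure `O=C(O)[C@@H]1CCCN1C(=O)/C=C/c1ccncc1-c1ccc2ccccc2c1`. In an assay on a protein complex for inhibition of CDK8/Cyclin C (Homo sapiens), with a stated time of 1 h (a lower number here means a stronger inhibitor, a higher number a weaker inhibitor), compound 1 gives "not determined" (no result reported), so no number anchors the starting point of this step. A related compound with the same double-bonded linker and amide carbonyl, compound 2, has the structure `Cn1ccc2cc(-c3cnccc3/C=C/C(=O)N3CCOCC3)ccc21`. In this assay, going by the values given here, compound 2 gives 247 nM, and that is the only measured value available here.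

Compound 3 has the structure `CN(C)C(=O)/C=C/c1ccncc1-c1ccc2ccccc2c1`. Its difference from compound 1 is counted as follows: dimethylamino in place of 2-carboxypyrrolidin-1-yl on a carbonyl carbon.

Because compound 1 has no value in this assay, the direction and size of the step from compound 1 to compound 3 cannot be read from any measured pair. Among the compounds with values here, the only guidance comes from compound 2, whose amide and linker resemble those of compound 3 while its aromatic group differs. On that basis compound 3 is expected to land close to the value of compound 2, within the range that compound 2 itself sets, rather than far from it.

For compound 3 in this assay the expected half-maximal inhibitory concentration is 300 nM, estimated to lie between 60 nM and 1500 nM.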

Compound 3, half-maximal inhibitory concentration: 30.1 nM
Beside the measured number, compound 3's estimate is 10-fold (1.00 log units) above it; the whole stated range lies above it.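

In this assay, going by these compounds alone, compound 1 gives "not determined" (no result reported) and compound 3 gives 30.1 nM so no step between compound 1 and compound 3 can be read. The compounds shown leave open what dimethylamino in place of 2-carboxypyrrolidin-1-yl on the carbonyl carbon does to inhibition. Nothing available here bears on the result for compound 3.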